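Aryl swap on the amide-type nitrogen in a ring

A few compounds are considered here, and "the series" means these few. Any claim that something is new, unique, unknown or untested is made for them only; others in the source may bear on it.

Measured in a functional assay on HCT-116 cells (Homo sapiens) for inhibition, read by sulforhodamine B assay, with a stated time of 48 h; a lower number here means a stronger inhibitor, a higher number a weaker inhibitor:
compound 1, `COc1cc(OC)cc(N2NC3=CC[C@@H](OC)O[C@@]3(c3ccncc3)CC2=O)c1`, 6500 nM
compound 2, `COc1ccc(N2NC3=CC[C@@H](OC)O[C@@]3(c3ccccc3)CC2=O)cc1`, 11300 nM
compound 3, `COc1cc(OC)cc(N2NC3=CC[C@@H](OC)O[C@@]3(C)CC2=O)c1`, 24300 nM

Compound 2 stands second highest of the three numbers. Compound 2 and compound 1 lie within the scatter of each other, so no order between them is claimed; compound 3 gives a higher number than compound 2, beyond the scatter. The two compounds differ in two places, so only their values are compared.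

Going by the values given here, the one step between single-point neighbours is a 3.7-fold higher number from compound 1 to compound 3 (0.57 log units; beyond the scatter). It concerns the saturated ring carbon, not the aryl group on the amide-type nitrogen in a ring, and therefore does not bear directly on the change now considered.

Compound 4, `CO[C@@H]1CC=C2NN(c3cc(F)cc(Cl)c3)C(=O)C[C@]2(c2ccccc2)O1`, differs from compound 2 in one place: 3-chloro-5-fluorophenyl in place of 4-methoxyphenyl on an amide-type nitrogen in a ring. Among the compounds with values here, no measured pair in the set varies this aryl group, so the data give no direction for the step. The expectation is a step of a 1.3-fold lower number from compound 2 to compound 4 (0.10 log units; within the scatter), that is none beyond the scatter, with a wide range on either side. In this assay compound 4 is estimated at 9000 nM, between 3000 nM and 30000 nM.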

Compound 4, half-maximal inhibitory concentration: 16200 nM
Beside the measured number, compound 4's estimate is 1.8-fold (0.26 log units) below it; the range from low to high includes it.
By their numbers in this assay, from the lowest: compounds 1, 2, 4 and 3 (each within the scatter of the next, the first and the last beyond it).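

In this assay, going by these compounds alone, the step of a 1.4-fold higher number from compound 2 to compound 4 (0.16 log units; within the scatter) is the first reading of the aryl group on the amide-type nitrogen in a ring, and it supports no claim of a difference between these two compounds. The hydrogen-bond acceptor counted on 4-methoxyphenyl is absent from 3-chloro-5-fluorophenyl, and the two groups have equal heavy-atom counts, so in this single pair, with phenyl on the saturated ring carbon, this exchange of substituents on the aromatic ring gives no shift beyond the scatter. No measurement at hand bears on this result, and no explanation of it is offered.

As far as these compounds go, whether the same exchange would read alike with pyridin-4-yl or methyl on the saturated ring carbon remains open, since compound 1 and compound 3 differ from compound 4 in more than one place. Also open, from the compounds shown here alone, is whether a non-aryl group on this nitrogen, such as a benzyl group or a longer alkyl chain, or a phenyl ring bearing a carboxylic acid or an amine, would give a step beyond the scatter.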